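A few compounds are considered here, and "the series" means these few. Any claim that something is new, unique, unknown or untested is made for them only; others in the source may bear on it.

Compound 1 `Nc1nc2cc(-c3nn(CCCC(=O)NO)c4ncnc(N)c34)ccc2o1`: > 50000 nM (a limit)
Compound 2 `Nc1nc2cc(-c3nn(CCCCCCCCCC(=O)NO)c4ncnc(N)c34)ccc2o1`: > 50000 nM (a limit)
Compound 3 `Nc1ncnc2c1c(-c1cnc3[nH]ccc3c1)nn2CCCCCCCCCC(=O)NO`: 23200 nM

In a functional assay on MCF7 cells (Homo sapiens) for inhibition, read by MTT assay, with a stated time of 72 h (on this read-out higher numbers stand for weaker inhibition and lower numbers for stronger inhibition), compound 2 gives > 50000 nM, which is a limit of the assay and not a number. Compound 1 gives > 50000 nM, also a limit. The overall picture is the limit of > 50000 nM in this assay, at which 2 of the 3 values shown sit. Only compound 3 gives a true number, 23200 nM.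

Compound 4 `Nc1nc2cc(-c3nn(CCC(=O)NO)c4ncnc(N)c34)ccc2o1` has not yet been measured. It keeps the core of compound 2 but changes the chain: hydroxycarbamoyl in place of 7-(hydroxycarbamoyl)heptyl on a saturated chain carbon, two bonds along the chain from an aromatic nitrogen, with hydroxycarbamoyl in place of 7-(hydroxycarbamoyl)heptyl on a saturated chain carbon, two bonds along the chain from an aromatic nitrogen.

Two measured steps can be consulted. The closer one is a step that the two limits leave unreadable from compound 1 to compound 2, also a chain change on this core, but it gives no size to carry over. The other is an at least 2.1-fold lower number from compound 2 to compound 3 (0.33 log units; beyond the scatter), which replaces a group on an aromatic carbon and leaves the chain untouched, so it bears little on this change.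

With no readable chain effect to go on, no change beyond the scatter is expected in this assay, in either direction. The expected step is a step that the limit leaves unreadable from compound 2 to compound 4. Compound 4 is estimated at 60000 nM, with an expected range from 30000 nM to 120000 nM, and the assay will most likely report only a limit.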

Compound 4, half-maximal inhibitory concentration: > 100000 nM
Compound 4: no number, only a limit; the forecaster's own chance of this, stated with the estimate: 85%; at least 1.6-fold (0.22 log units) between middle value and limit.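

Compound 4 gives only a limit of the assay, not a number, and compound 1 and compound 2 also give limits, so the steps from compound 2 to compound 4 and from compound 1 to compound 4 cannot be read. The compounds shown leave open how much the chain matters on the core of compound 2.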